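Series notes on tolerated concentration: compound 3 to compound 4

A few compounds are considered here, and "the series" means these few. Any claim that something is new, unique, unknown or untested is made for them only; others in the source may bear on it.

Compound 1 `COc1cc(-c2nnc(SCc3c(F)cccc3F)o2)ccc1O`: 575000 nM
Compound 2 `COc1cc(-c2nnc(SCc3ccc(F)cc3F)o2)ccc1O`: 520000 nM
Compound 3 `COc1cc(-c2nnc(SCc3ccc(F)cc3)o2)ccc1O`: 685000 nM

In an ADME assay on cells (Mus musculus, strain BALB/c) for cytotoxicity, read by MTT assay, with a stated time of 24 h (a lower number here means that less compound is tolerated, a higher number that more compound is tolerated), the three measured compounds sit close together. Compound 3 carries the highest of the three numbers, yet its steps to the others stay within the scatter: a 1.2-fold higher number from compound 1 to compound 3 (0.08 log units; within the scatter) and a 1.3-fold higher number from compound 2 to compound 3 (0.12 log units; within the scatter). The step of a 1.1-fold lower number from compound 1 to compound 2 (0.04 log units; within the scatter) is likewise within the scatter. Compound 4 `COc1cccc(CSc2nnc(-c3ccc(O)c(OC)c3)o2)c1` has not yet been measured. It differs from compound 3 as follows: 3-methoxyphenyl in place of 4-fluorophenyl on a saturated chain carbon bound to a sulfur. Among the measured compounds shown here, the steps bearing on this position are the two cited above, both small, and no measured compound carries a methoxyphenyl there, so nothing in the measured set points to a step beyond the scatter. The expected step is a 1.1-fold lower number from compound 3 to compound 4 (0.04 log units; within the scatter). Compound 4 is therefore estimated at 620000 nM, with a range from 300000 nM to 1250000 nM.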

Compound 4, half-maximal cytotoxic concentration: 389000 nM
Compound 4: the middle estimate sits 1.6-fold (0.20 log units) above what was measured; the measured number falls inside the stated range.
By their numbers in this assay, from the lowest: compounds 4, 2, 1 and 3 (each within the scatter of the next).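

In this assay, the position on a saturated chain carbon bound to a sulfur now holds a group without fluorine, and all three new steps stay within the scatter (a 1.8-fold lower number from compound 3 to compound 4 (0.25 log units; within the scatter) and a 1.3-fold lower number from compound 2 to compound 4 (0.13 log units; within the scatter) and a 1.5-fold lower number from compound 1 to compound 4 (0.17 log units; within the scatter)). The entering 3-methoxyphenyl brings 1 hydrogen-bond acceptor where 4-fluorophenyl has 0, and no step beyond the scatter comes with it. No measurement at hand offers an explanation for these numbers. Going by these compounds, whether an amine, a carboxylic acid or a longer chain at this position would give a step beyond the scatter stays open.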